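The source may hold more compounds than are shown below. What is called first, only, known or untested is meant among the compounds shown, and "the series" means these compounds.

Compound 1 `Cn1ccc2c(Oc3ccc(NC(=O)c4nn(-c5ccc(Cl)cc5)ccc4=O)cc3F)ccnc21` and compound 2 `Cn1ccc2c(Oc3ccc(NC(=O)c4nn(-c5ccccc5)ccc4=O)cc3F)ccnc21` share one core and differ only in the ring that sits on an aromatic nitrogen. In a functional assay on A549 cells (Homo sapiens) for cytotoxicity, read by MTT assay, with a stated time of 72 h (on this read-out lower numbers stand for stronger inhibition and higher numbers for weaker inhibition), compound 1 gives > 60000 nM, which is a limit of the assay rather than a measured number. In this assay compound 2 likewise gives > 60000 nM, again a limit. The step that the two limits leave unreadable from compound 1 to compound 2, hydrogen in place of chloro on an aromatic carbon, therefore cannot be read, because of the limit of > 60000 nM in this assay, at which 2 of the 2 values shown sit. Compound 3 `Cn1ccc2c(Oc3ccc(NC(=O)c4nn(-c5ccc(Cl)c(F)c5)ccc4=O)cc3F)ccnc21` has not yet been measured; it carries 4-chloro-3-fluorophenyl in place of phenyl on an aromatic nitrogen. For the measured compounds named here, the only measured step concerns the same ring and gives no readable size, so no direction beyond the scatter can be drawn from it. Compound 3 is therefore expected to give about 80000 nM, within 30000 nM to 200000 nM, and most likely to be reported again only as a limit. This estimate means an expected step that the limit leaves unreadable from compound 2 to compound 3.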

Compound 3, half-maximal inhibitory concentration: > 60000 nM
Compound 3 gave a limit, no number (the forecaster's own chance of this, stated with the estimate: 80%); the middle value lies beyond the limit too.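

No new step can be read between compound 1, compound 2 and compound 3, because each result is a limit of the assay and not a number: the limit of > 60000 nM in this assay, at which 3 of the 3 values shown sit.

The compounds shown leave open how strongly each acts in this assay, and whether changing the ring on the aromatic nitrogen matters there at all.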